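The source may report more compounds than this note shows. Statements on the series, on what has been measured and on what is new or still open speak of the compounds shown alone.

Measured so far:
Compound 1, `COc1cc(C)c(S(=O)(=O)N(C)CCOCC(=O)N2CCN(CCN(C)C)CC2)c(C)c1`, gives 7.4 in a functional assay on Umbilical vein for antagonist activity at B1 bradykinin receptor (Homo sapiens), using Schild analysis, with a stated time of 30 min; a lower number here means a less potent compound, a higher number a more potent compound, by a factor of ten per unit of this negative logarithm.
Compound 2, `COc1cc(C)c(S(=O)(=O)N(C)CCOCC(=O)N2CCN([C@@H]3CN4CCC3CC4)CC2)c(C)c1`, gives 8.1 in this assay.

Within the data shown here, compound 2 stands highest of the two numbers; the single measured step, a number 0.70 log units higher from compound 1 to compound 2 (beyond the scatter), lies beyond the scatter and is modest in size. Compound 3, `COc1cc(C)c(S(=O)(=O)N(C)CCOCC(=O)N2CCN(CC3CCN(C)CC3)CC2)c(C)c1`, has not been measured in this assay. It differs from compound 2 by a group of 8 heavy atoms (7 carbon, 1 nitrogen; one six-membered non-aromatic ring with 1 hetero atom) in place of a group of 8 heavy atoms (7 carbon, 1 nitrogen; 2 six-membered non-aromatic rings with 1 hetero atom each), on an amine nitrogen in a ring. Among the measured compounds shown here, the one step that bears on this is a number 0.70 log units higher from compound 1 to compound 2 (beyond the scatter), which swapped a group with no ring for one with two rings and raised the number. For the measured compounds named here, compound 3 keeps the same count of atoms but has only one ring in that group, so something between the two measured numbers seems plausible. A step in this assay of about a number 0.30 log units lower from compound 2 to compound 3 (within the scatter) is expected for compound 3, downward, probably within the scatter. The estimate for compound 3 is 7.8, within a range of 7.2 to 8.4.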

Compound 3, negative logarithm of the antagonist equilibrium constant: 8.6
Compound 3: middle estimate off by 0.80 log units, on the low side; measured number above the stated range.
By their numbers in this assay, from the lowest: compound 1; then compound 2; then compound 3.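

In this assay, the step of a number 0.50 log units higher from compound 2 to compound 3 (beyond the scatter) shows that the two-ring group is not needed at this amine nitrogen: (1-methylpiperidin-4-yl)methyl, with one six-membered ring and the same count of heavy atoms, gives the higher number. The open-chain group of compound 1 can now be compared with this single-ring group, and the step of a number 1.20 log units higher from compound 1 to compound 3 (beyond the scatter) is large, so a ring here can go with a clear gain even when the second ring is absent. No measurement given here explains either step.

Going by these compounds, whether the methyl on the piperidine nitrogen matters remains open, since an ethyl group or a plain hydrogen there would test it. A longer chain joining the piperidine to the amine nitrogen could also give a different number.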